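Aminofluoropyridyl in Place of Chlorophenyl: Expected Efficacy

A few compounds are considered here, and "the series" means these few. Any claim that something is new, unique, unknown or untested is made for them only; others in the source may bear on it.

In an in vitro functional assay on HEK285-7 cells for antagonist activity at prostaglandin D2 receptor 2 (Homo sapiens), read by BRET and beta-arrestin recruitment (a lower number here means a smaller maximal response, a higher number a larger maximal response), compound 2 `O=C(O)Cc1sc(C(c2ccc(F)cc2)c2ccc(F)cc2)nc1-c1ccc(Cl)cc1` gives 80%. Compound 1 `COc1ccc(OC)c(-c2nc(C(c3ccccc3)c3ccccc3)sc2CC(=O)O)c1` gives 80%, and compound 3 `O=C(O)Cc1sc(C(c2ccccc2)c2ccc(F)cc2)nc1-c1ccc(Cl)cc1` gives 80%, so compound 2 stands level with both at the digits shown, within the scatter. Compound 4 `Nc1cc(-c2nc(C(c3ccc(F)cc3)c3ccc(F)cc3)sc2CC(=O)O)cc(F)n1` differs from compound 2 by 2-amino-6-fluoropyridin-4-yl in place of 4-chlorophenyl on an aromatic carbon. Among the compounds with values here, the only measured step, no change at the digits printed from compound 2 to compound 3 (within the scatter), concerns a change elsewhere in the structure and showed no movement. Across compounds 1, 2 and 3 the maximal response has stayed the same within the scatter, and nothing measured points to a shift in either direction. Compound 4 is therefore expected to show no change at the digits printed from compound 2 to compound 4 (within the scatter), no step beyond the scatter. Compound 4 is estimated at 80%, between 62% and 95%.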

Compound 4, largest response reached (reported as efficacy), in percent of the reference or control that the assay uses: 30%
Beside the measured number, compound 4's estimate is 50 percentage points above it, and the stated range ends above it.
By their numbers in this assay, from the lowest: compound 4; then compounds 1, 2 and 3 (each within the scatter of the next).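

Where no change at the digits printed from compound 2 to compound 3 (within the scatter) left the response unmoved at another place in the structure, the aromatic carbon next to the ring nitrogen proves sensitive: in this assay, 2-amino-6-fluoropyridin-4-yl in place of 4-chlorophenyl gives a number 50 percentage points lower from compound 2 to compound 4 (beyond the scatter). The maximal response can therefore move well beyond the scatter within this series, and it does so through this group. Nothing available explains the drop. This single change alters the ring, the amine and the fluoro substituent together, so the compounds shown leave open which of these accounts for it. A plain pyridin-4-yl or a 3-aminophenyl group at this position would begin to separate them.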